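Compound 3 Before Its Number Is Known

This account rests on a few compounds, and the source may have more. Where it says the series, first, only, none or still open, it means among the compounds named here.

Measured so far:
compound 1 `Cc1ccccc1NC(=O)N[C@H](C)c1ccccc1` gives 100%
compound 2 `Cc1ccccc1NC(=O)N[C@@H](C)c1ccccc1` gives 99%

Of the compounds shown here, two have been measured in an ADME assay on the whole organism with Oryza sativa as the target, tested at 1 uM; on this read-out higher numbers stand for a weaker effect at the one concentration tested and lower numbers for a stronger effect. Compound 1 stands at the higher of the two numbers, and compound 2 sits a step of a number 1 percentage points lower from compound 1 to compound 2 (within the scatter) away from it. That pair differs only in one respect, (the fact that compounds 1 and 2 differ only in the configuration as drawn), so the step between them says nothing about adding or removing a group.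

Compound 3 `CCc1ccccc1NC(=O)N[C@H](C)c1ccccc1` is the next compound in line. It differs from compound 1 by methyl in place of hydrogen on a saturated chain carbon bound to an aromatic carbon. For the measured compounds named here, no measured step bears on this change: the only step seen so far concerns configuration alone, and it lies within the scatter. What can be said is that compound 1 gives 100%, and the change in compound 3 is a small one. On that basis the step of a number 3 percentage points lower from compound 1 to compound 3 (within the scatter) is expected to be small and not beyond the scatter. Compound 3 is therefore estimated at 97%, within a range from 85% to 100%.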

Compound 3, a percentage reported as activity, at one concentration (the size of the read-out at that concentration, not a potency): 100%
Estimate against measurement, compound 3: 3 percentage points below, and the stated range covers the measured number.
By their numbers in this assay, from the lowest: compounds 2, 1 and 3 (each within the scatter of the next).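

In this assay, the position now has a reading for a change in the atoms themselves: at the saturated chain carbon bound to an aromatic carbon, methyl in place of hydrogen, which reads as methyl to ethyl when cut one bond further out, gives no change at the digits printed from compound 1 to compound 3 (within the scatter). For the compounds shown here, the earlier pair offered only a step in configuration, so this is the first sign of how the read-out responds when the group on this carbon grows, and for this one added carbon the printed values do not separate compound 3 from compound 1. Nothing available on this change accounts for that result, and the single known fact about the earlier pair does not bear on it.

From the compounds shown here alone, what a longer chain such as propyl, or a hydroxyl or an amine, would give at this place remains open, since one small step says nothing about larger or different groups. Also open, going by these compounds, is whether the ethyl compound drawn with the opposite configuration would stay as close to compound 3 as compound 2 stays to compound 1.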